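Bromo in place of nitro on a shared core

A few compounds are considered here, and "the series" means these few. Any claim that something is new, unique, unknown or untested is made for them only; others in the source may bear on it.

Measured so far:
compound 1 `COc1ccc(/C=C2\Cc3c(cc(OC)c(OC)c3OC)C2=O)cc1[N+](=O)[O-]`: 3490 nM
compound 2 `COc1cc(/C=C2\Cc3c(cc(OC)c(OC)c3OC)C2=O)cc(OC)c1OC`: 5840 nM
compound 3 `COc1cc2c(c(OC)c1OC)C/C(=C\c1cc(OC)c(OC)c(OC)c1OC)C2=O`: > 10000 nM (a limit)

For the measured compounds named here, in a functional assay on MDA-MB-231 cells (Homo sapiens) for antiproliferative activity, read by MTT assay, with a stated time of 48 h (a higher number here means a weaker inhibitor of growth, a lower number a stronger inhibitor of growth), compound 1 at 3490 nM and compound 2 at 5840 nM lie within the scatter of each other, and they are the only two true numbers available. Compound 3 reports > 10000 nM which is a limit and not a number.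

The unmeasured compound 4 `COc1ccc(/C=C2\Cc3c(cc(OC)c(OC)c3OC)C2=O)cc1Br` keeps the core of compound 1 and carries bromo in place of nitro on an aromatic carbon, ortho to a methoxy group: bromo in place of nitro on an aromatic carbon.

Going by the values given here, the only measured step, methoxy in place of hydrogen on an aromatic carbon, gives an at least 1.7-fold higher number from compound 2 to compound 3 (0.23 log units; that floor lies within the scatter) and its floor lies within the scatter. Among the compounds with values here, no measured step touches the nitro group, so this one bears on the change only weakly, and no step beyond the scatter is expected in this assay in either direction. The expected step is a 1.2-fold lower number from compound 1 to compound 4 (0.07 log units; within the scatter) and no larger. In this assay compound 4 is expected at 3000 nM within an estimated range from 1000 nM to 9000 nM.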

Compound 4, concentration for 50% growth inhibition: 678 nM
Beside the measured number, compound 4's estimate is 4.4-fold (0.65 log units) above it; measured number below the stated range.
By their numbers in this assay, from the lowest: compound 4; then compounds 1 and 2 (each within the scatter of the next). At a limit, above all of these: compound 3.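

In this assay, bromo in place of nitro on an aromatic carbon, ortho to a methoxy group, gives a 5.1-fold lower number from compound 1 to compound 4 (0.71 log units; beyond the scatter), the only step shown that lies beyond the scatter. For the compounds shown here, this position therefore responds to the group it carries, which the earlier compounds could not show: no earlier step touched the nitro group, and compound 1 and compound 2 lie within the scatter of each other. Nothing given here bears on why bromo gives the lower number.

The compounds shown leave open how chloro, an amine or a carboxylic acid would read at this same position in this assay. They also leave open whether the step would persist if the methoxy group ortho to this position were replaced by hydrogen.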